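This account rests on a few compounds, and the source may have more. Where it says the series, first, only, none or still open, it means among the compounds named here.

Working notes on this series in an ADME assay on HepG2 2.2.15 cells (Homo sapiens) for cytotoxicity; on this read-out lower numbers stand for higher toxicity in this test and higher numbers for lower toxicity in this test. Compound 1 `O=C(Nc1ncc(Cc2ccc(Br)cc2)s1)c1cccs1` is reported as > 50000 nM; this is a limit of the assay, not a number. Compound 2 `O=C(Nc1ncc(C(OCc2ccc(F)cc2F)c2ccccc2)s1)c1cccs1` is entered as "not toxic" (no number reported) with no figure given. Compound 3 `CC(C)(C)C(=O)Nc1ncc(C(Oc2ccc3cc(Br)ccc3c2)c2ccc(Cl)cc2)s1` likewise stands as "not toxic" (no number reported), again without a single number. So none of the three entries in this assay is a measured number: compound 3 sits with compound 2 in the unnumbered group, while compound 1 sits at the ceiling itself (the limit of > 50000 nM in this assay, at which 1 of the 3 values shown sits).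

Compound 4 `O=S(=O)(Nc1ncc(C(Oc2ccc3cc(Br)ccc3c2)c2ccc(Cl)cc2)s1)c1ccc(Cl)nc1` is the next compound to be measured in this assay. Against compound 3 the change is (6-chloropyridin-3-yl)sulfonyl in place of (tert-butyl)carbonyl on a nitrogen on an aromatic ring. Among the compounds with values here, no measured step between any pair of compounds exists here, so nothing in the data sets a size or direction for this change; the expectation is none beyond the scatter, with the value remaining at or past the ceiling. Like compound 3, compound 4 is expected to remain non-toxic, estimated at 50000 nM, within 20000 nM to 150000 nM, and most likely again reported only as a limit.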

Compound 4, half-maximal cytotoxic concentration: "not toxic" (no number reported)
For compound 4 the study gives words and no number; the estimate stays without a comparison.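

In this assay, within the data shown here, compound 3 and compound 4 are both entered as not toxic without a number, so no step between them can be read. The compounds shown leave open whether (6-chloropyridin-3-yl)sulfonyl in place of (tert-butyl)carbonyl shifts the half-maximal cytotoxic concentration at all.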